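Fluoro to Methyl on the Aromatic Ring: Expected Stability

The source may hold more compounds than are shown below. What is called first, only, known or untested is meant among the compounds shown, and "the series" means these compounds.

Measured compounds:
compound 1 `CCc1cnc(N2CCC(c3nc(COc4ccc(-n5cnnn5)cc4)cs3)CC2)nc1`, an ADME assay on microsomes from liver (Rattus norvegicus) for metabolic stability, with a stated time of 30 min (a lower number here means that less of the compound is left, a higher number that more of the compound is left), 20.6%
compound 2 `CCc1cnc(N2CCC(c3nc(COc4ccc(/C=C5\CC(=O)NC5=O)cc4F)cs3)CC2)nc1`, this assay 33%

Compound 2 stands highest of the two numbers; compound 1 lies lower by a gap beyond the usual scatter. Compound 3 `CCc1cnc(N2CCC(c3nc(COc4ccc(/C=C5\CC(=O)NC5=O)cc4C)cs3)CC2)nc1` has not yet been measured. It differs from compound 2 in one place: methyl in place of fluoro on an aromatic carbon. For the measured compounds named here, no step between measured compounds shows what such a swap does, so any expectation rests on compound 2 alone. A small step downward, or none beyond the scatter, is expected, a number 6 percentage points lower from compound 2 to compound 3 (within the scatter). Compound 3 is estimated at 27%, within a range from 12% to 45%.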

Compound 3, percent of the compound remaining: 32.4%
Compound 3: middle estimate off by 5.4 percentage points, on the low side; the measured number falls inside the stated range.
By their numbers in this assay, from the lowest: compound 1; then compounds 3 and 2 (each within the scatter of the next).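

In this assay methyl in place of fluoro on this aromatic carbon, ortho to a large group, gives a number 0.6 percentage points lower from compound 2 to compound 3 (within the scatter) and so the two groups cannot be told apart at this position. Compound 1 and compound 2 differ in more than one place, so they could not show this. No measurement at hand explains the result. From the compounds shown here alone, whether an amine, a methoxy group or plain hydrogen at this position would also leave the number unmoved stays open. So does whether the same swap behaves alike on a different core.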